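Trimming the Ester Acyl Group of Compound 1 to Methyl

This account rests on a few compounds, and the source may have more. Where it says the series, first, only, none or still open, it means among the compounds named here.

Compound 1 `COc1cc2c(c(O)c1C(=O)/C=C/c1ccc(OC(=O)c3cccs3)cc1)CCC(C)(C)O2` carries a thiophen-2-yl carbonyl ester on its phenyl ring. In an assay on HEK293T cells for inhibition of nuclear factor NF-kappa-B complex (Homo sapiens), read by a luciferase reporter (a higher number here means a weaker inhibitor, a lower number a stronger inhibitor), compound 1 reaches only a limit of the assay, > 30000 nM. Compound 2 `CCCCC(=O)Oc1ccc(/C=C/C(=O)c2c(OC)cc3c(c2O)CCC(C)(C)O3)cc1` is the same scaffold with a pentanoyl ester, and in this assay compound 2 also stands at a limit, > 30000 nM. Compound 3 `COc1cc2c(c(O)c1C(=O)/C=C/c1ccc(OC(=O)c3ccccc3F)cc1)CCC(C)(C)O2`, bearing a 2-fluorobenzoyl ester, gives in this assay a limit as well, > 30000 nM. All three values sit at the limit of > 30000 nM in this assay, at which 3 of the 3 values shown sit, so the step from compound 1 to compound 2 is a step that the two limits leave unreadable from compound 1 to compound 2, the step from compound 1 to compound 3 is a step that the two limits leave unreadable from compound 1 to compound 3, and the step from compound 2 to compound 3 is a step that the two limits leave unreadable from compound 2 to compound 3: none of them has a readable size or direction.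

Compound 4 `COc1cc2c(c(O)c1C(=O)/C=C/c1ccc(OC(C)=O)cc1)CCC(C)(C)O2` differs from compound 1 by methyl in place of thiophen-2-yl on a carbonyl carbon. The three steps that bear on this change are all unreadable, and every varied acyl group leaves the series at the assay limit. The step from compound 1 to compound 4 is therefore expected to be a number no higher from compound 1 to compound 4 (the limit leaves the size open), with no readable shift. Compound 4 is estimated at 30000 nM, within a range from 10000 nM to 100000 nM, and most likely it will again be reported only as a limit.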

Compound 4, half-maximal inhibitory concentration: > 30000 nM
Compound 4 gave a limit, no number; the forecaster's own chance of this, stated with the estimate: 85%; the middle value lies on the limit itself.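

In this assay compound 4 also gives only a limit, > 30000 nM. Its steps from compound 1, compound 2 and compound 3 therefore cannot be read: the limit of > 30000 nM in this assay, at which 4 of the 4 values shown sit.

The compounds shown leave open how strongly any of these four esters inhibits in this assay, and whether any acyl group on this core would give a measurable number.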